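Sulfonyl aryl exchange from compound 1 to compound 3

The source may hold more compounds than are shown below. What is called first, only, known or untested is meant among the compounds shown, and "the series" means these compounds.

Growth inhibition of DAN-G cells, measured in a functional assay on DAN-G cells (Homo sapiens) for cytotoxicity, with a stated time of 96 h; on this read-out lower numbers stand for stronger inhibition of growth and higher numbers for weaker inhibition of growth:
- compound 1 `O=C(Oc1cccc2cccnc12)c1cc2c(cc1Cl)SC(N(c1ccc(F)cc1)S(=O)(=O)c1ccc(Br)s1)=NS2(=O)=O`: compound 1 gives 8200 nM
- compound 2 `Cc1cc2c(cc1Cl)SC(N(c1ccc(Cl)cc1)S(=O)(=O)c1ccccc1)=NS2(=O)=O`: compound 2 gives 9900 nM

Compound 1 holds the lower of the two numbers in this assay, but compound 2 sits within the scatter of it, so the two read as equivalent. Among the measured compounds shown here, no pair of measured compounds differs in only one place, so no single-change step is available for this series.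

Compound 3 `O=C(Oc1cccc2cccnc12)c1cc2c(cc1Cl)SC(N(c1ccc(F)cc1)S(=O)(=O)c1ccc(Cl)cc1)=NS2(=O)=O` is not yet measured. It differs from compound 1 in one place: 4-chlorophenyl in place of 5-bromothiophen-2-yl on a sulfonyl sulfur. Both measured compounds carry a six-membered carbon ring on that sulfonyl sulfur or a five-membered one, and give numbers within the scatter of each other, so no step beyond the scatter is expected for the change from compound 1 to compound 3 in this assay; the expected step is a 1.0-fold higher number from compound 1 to compound 3 (0.02 log units; within the scatter). Compound 3 is estimated at 8500 nM, with a range from 4000 nM to 18000 nM.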

Compound 3, concentration for 50% growth inhibition: 9300 nM
Beside the measured number, compound 3's estimate is 1.1-fold (0.04 log units) below it; the measured number falls inside the stated range.
By their numbers in this assay, from the lowest: compounds 1, 3 and 2 (each within the scatter of the next).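

Among the compounds shown here, this is the first single-change step. In this assay, 4-chlorophenyl in place of 5-bromothiophen-2-yl on a sulfonyl sulfur whose other neighbour is the sulfonamide nitrogen gives a 1.1-fold higher number from compound 1 to compound 3 (0.05 log units; within the scatter), so on the core of compound 1 this position takes either aromatic ring and the two compounds read as equivalent. No measurement at hand bears on why the two rings read alike.

The compounds shown leave open whether a methyl group or a longer alkyl chain on the same sulfonyl sulfur, with no aromatic ring there, would also read as equivalent. They also leave open whether an amine or a carboxylic acid carried on the aromatic ring would hold the number within the scatter or move it beyond.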